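A few compounds are considered here, and "the series" means these few. Any claim that something is new, unique, unknown or untested is made for them only; others in the source may bear on it.

Compounds measured so far:
Compound 1, `N#Cc1ccc(-c2cc3n(n2)CCCC3)nc1`, in a functional assay on HEK293 cells for negative allosteric modulation of metabotropic glutamate receptor 5 (Rattus norvegicus), read by FLIPR and calcium flux, with a stated time of 170 s; on this read-out lower numbers stand for stronger inhibition and higher numbers for weaker inhibition: > 10000 nM
Compound 2, `O=C(Nc1ccccn1)c1cc2n(n1)CCCC2`, in this assay: 364 nM
Compound 3, `Clc1cccc(-c2cc3n(n2)CCCC3)c1`, in this assay: 77 nM

The value of compound 1 is a limit of the assay and not a number, which is also what the limit of > 10000 nM in this assay, at which 1 of the 3 values shown sits, shows. Among the two numbers in hand, compound 3 has the lowest, and compound 2 stands next with a higher number, a gap beyond the usual scatter. The shared core carries a chloro group on a six-membered carbon ring in compound 3.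

Compound 4, `Fc1cccc(-c2cc3n(n2)CCCC3)c1`, has not yet been tested. The change from compound 3 to compound 4 is fluoro in place of chloro on an aromatic carbon. Among the compounds with values here, no pair of measured compounds shows this kind of swap, so the size of the step is open. A modest rise, beyond the scatter, is the expectation here, as a step of a 3.2-fold higher number from compound 3 to compound 4 (0.51 log units; beyond the scatter). Compound 4 is thus expected to give about 250 nM in this assay, with a likely range from 80 nM to 800 nM.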

Compound 4, half-maximal inhibitory concentration: 1570 nM
The estimate for compound 4 lay 6.3-fold (0.80 log units) below the measured number, outside the stated range (above it).
By their numbers in this assay, from the lowest: compound 3; then compound 2; then compound 4. At a limit, above all of these: compound 1.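

Replacing chloro with fluoro on this aromatic carbon gives a 20-fold higher number from compound 3 to compound 4 (1.31 log units; beyond the scatter) in this assay, a large loss of inhibition. Within the data shown here, only one heavy atom changes, and no ring, hydrogen-bond donor, hydrogen-bond acceptor or net charge enters or leaves, so the read-out at this position clearly depends on which halogen is present. Nothing measured here explains why these two halogens differ so much.

The compounds shown leave open how other groups on this same carbon, such as bromo, methyl, methoxy or an amine, would compare with chloro, so it remains unknown whether chloro is the best choice here. They also leave open whether the same swap would produce a step of similar size on another carbon of this ring.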